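The source may report more compounds than this note shows. Statements on the series, on what has been measured and on what is new or still open speak of the compounds shown alone.

Measured so far:
- compound 1, `CC(=O)N1CCC(C(=O)N2CC[C@H](C(=O)N(C)Cc3cc(C(F)(F)F)cc(C(F)(F)F)c3)[C@@H](c3cccc(C)c3)C2)CC1`: 0.14 nM
- compound 2, `CC(=O)N1CCC(C(=O)N2CC[C@H](C(=O)N(C)Cc3cc(C(F)(F)F)cc(C(F)(F)F)c3)[C@@H](c3ccc(F)cc3C)C2)CC1`: 0.047 nM

In an assay on IM-9 cells for displacement of a labelled ligand from Substance-P receptor (Homo sapiens), read by scintillation counting, with a stated time of 30 min (a higher number here means a weaker inhibitor, a lower number a stronger inhibitor), compound 2 gives the lowest number of the two, with compound 1 next at a 3.0-fold lower number from compound 1 to compound 2 (0.47 log units; beyond the scatter). Compound 3, `CC(=O)N1CCC(C(=O)N2CC[C@H](C(=O)N(C)Cc3cc(C(F)(F)F)cc(C(F)(F)F)c3)[C@@H](c3ccccc3C(C)C)C2)CC1`, has not yet been measured; it differs from compound 2 by 2-isopropylphenyl in place of 4-fluoro-2-methylphenyl on a saturated ring carbon. Going by the values given here, the only measured step touching this part of the structure is the one from compound 1 to compound 2, which was modest, so the aryl group does shift the numbers, but in an unknown direction here. Compound 3 is therefore expected to land near compound 2, with a step of a 3.2-fold higher number from compound 2 to compound 3 (0.50 log units; beyond the scatter) estimated, at about 0.15 nM (range 0.04 nM to 0.6 nM).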

Compound 3, half-maximal inhibitory concentration: 0.21 nM
The estimate for compound 3 lay 1.4-fold (0.15 log units) below the measured number; measured number inside the range.
By their numbers in this assay, from the lowest: compound 2; then compounds 1 and 3 (each within the scatter of the next).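

In this assay, swapping 4-fluoro-2-methylphenyl for 2-isopropylphenyl gives a 4.5-fold higher number from compound 2 to compound 3 (0.65 log units; beyond the scatter), so this position responds to the choice of aryl group, and not every substituted phenyl matches compound 2. Swapping 3-methylphenyl for 2-isopropylphenyl gives a 1.5-fold higher number from compound 1 to compound 3 (0.18 log units; within the scatter), so those two groups cannot be told apart here. Nothing available explains either step. Going by these compounds, it remains open whether the fluorine of compound 2 matters on its own. These compounds also do not show how a phenyl ring bearing a methoxy group or a nitrile would behave.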